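The source may report more compounds than this note shows. Statements on the series, on what has been measured and on what is new or still open speak of the compounds shown alone.

Working notes on the series.

Compound 1 `O=C(/C=C/c1ccc(OCc2nc(C3CCN(Cc4ccccc4)CC3)no2)cc1)NO` carries a benzyl group on the piperidine nitrogen of the shared core. In an assay on isolated protein for inhibition of protein deacetylase HDAC6 (Homo sapiens), read by fluorescence, with a stated time of 1 h, tested at 100 nM (a higher number here means more inhibition at the concentration tested (going by the name of the read-out), a lower number less inhibition), compound 1 gives 71%, the highest of the three numbers recorded. Compound 2 `O=C(/C=C/c1ccc(OCc2nc(C3CCN(Cc4ccccc4F)CC3)no2)cc1)NO` gives 68% in this assay, and compound 3 `O=C(/C=C/c1ccc(OCc2nc(C3CCN(Cc4ccccc4[N+](=O)[O-])CC3)no2)cc1)NO` gives 63%. The steps between them are a number 3 percentage points lower from compound 1 to compound 2 (within the scatter), a number 8 percentage points lower from compound 1 to compound 3 (within the scatter) and a number 5 percentage points lower from compound 2 to compound 3 (within the scatter), each within the scatter, so the three compounds are not separated by this assay.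

Compound 4 `O=C(CCc1ccc(OCc2nc(C3CCN(Cc4ccccc4)CC3)no2)cc1)NO` differs from compound 1 by 2-(hydroxycarbamoyl)ethyl in place of 2-(hydroxycarbamoyl)ethenyl on an aromatic carbon. Within the data shown here, none of the measured steps touches this part of the molecule: all three concern the distal benzyl ring, and each lies within the scatter. Among the measured compounds shown here, no measured precedent therefore bears on this change, and the expectation rests only on the value of compound 1 71% as the starting point, with a wide range around it. A step of a number 16 percentage points lower from compound 1 to compound 4 (beyond the scatter) is estimated from compound 1 to compound 4, downward, though it may well fall within the scatter. Compound 4 is expected to give 55% in this assay, in the range 30% to 75%.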

Compound 4, a percentage reported as inhibition, at one concentration (the size of the read-out at that concentration, not a potency): 22%
Beside the measured number, compound 4's estimate is 33 percentage points above it; the whole stated range lies above it.
By their numbers in this assay, from the lowest: compound 4; then compounds 3, 2 and 1 (each within the scatter of the next).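

The double bond of the 2-(hydroxycarbamoyl)ethenyl group matters in this assay: with 2-(hydroxycarbamoyl)ethyl in its place, and nothing else changed, the result is a number 49 percentage points lower from compound 1 to compound 4 (beyond the scatter) in a single large step. Among these compounds, the earlier compounds varied only the distal benzyl ring and stayed within the scatter of one another, so this position, para to a large group, is the first where one change separates two compounds. Nothing measured here accounts for the size of this step.

On these data alone, it remains open whether a longer chain, such as 3-(hydroxycarbamoyl)propyl, would give a number nearer that of compound 1 or compound 4. Also open, as far as these compounds go, is whether a carboxylic acid in place of the hydroxycarbamoyl group would retain any inhibition at this position.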